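The source may report more compounds than this note shows. Statements on the series, on what has been measured and on what is new or still open speak of the compounds shown alone.

Measured so far:

compound 1 `CC1=C(C(=O)OC(C)(C)C)C(c2ccsc2)NC(=O)N1`: 15% in an assay on membranes from CHO cells for displacement of a labelled ligand from adenosine receptor A1 (Homo sapiens), read by scintillation counting, with a stated time of 60 min, tested at 1 uM; on this read-out higher numbers stand for more inhibition at the one concentration tested (going by the name of the read-out) and lower numbers for less inhibition
compound 2 `CCOC(=O)C1=C(C)N(C)C(=O)NC1c1ccsc1`: 32%

Of the two numbers, compound 2 stands highest; compound 1 is the nearest and lies beyond the usual scatter below it. Compound 1 and compound 2 differ from each other in more than one place, so nothing more is drawn from that pair than what the two numbers show.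

Compound 3 `CC1=C(C(=O)OC(C)(C)C)C(c2ccsc2)NC(=O)N1C` keeps the core of compound 2 and differs from it in one place: tert-butyl in place of ethyl on an oxygen next to a carbonyl group. Among the compounds with values here, no pair of measured compounds isolates this change, so there is no measured step to lean on. Within the data shown here, the only measured compound that already carries a tert-butyl ester, compound 1, gives 15%, but it also differs from compound 2 in another place, so its value cannot be read as the effect of this change alone.

For the step from compound 2 to compound 3 a small decrease is expected, a number 7 percentage points lower from compound 2 to compound 3 (within the scatter), which may well stay within the scatter. Compound 3 is therefore estimated at 25%, with a range from 5% to 45%.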

Compound 3, a percentage reported as inhibition, at one concentration (the size of the read-out at that concentration, not a potency): 18%
The estimate for compound 3 lay 7 percentage points above the measured number; low and high end bracket the measured number.
By their numbers in this assay, from the lowest: compounds 1 and 3 (each within the scatter of the next); then compound 2.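

In this assay, the swap of ethyl for tert-butyl on an oxygen next to a carbonyl group can now be read on its own, and the larger group comes with a modest loss of inhibition (a number 14 percentage points lower from compound 2 to compound 3 (beyond the scatter)). The earlier pair could not show this, as compound 1 and compound 2 differ in more than one place. The second new pair isolates methyl in place of hydrogen on an amide-type nitrogen in a ring, and that change makes no difference that stands clear of the usual scatter (a number 3 percentage points higher from compound 1 to compound 3 (within the scatter)), while nothing measured explains either result.

On these data alone, the ester step has been read only with methyl on that ring nitrogen, so whether it holds with hydrogen there remains open. Also open is what a propyl chain or a benzyl group would do in place of the ethyl, or a carboxylic acid in place of the whole ester, and since each number comes from a single concentration, the potency of these compounds remains unknown too.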